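The source may report more compounds than this note shows. Statements on the series, on what has been measured and on what is new or still open speak of the compounds shown alone.

In a functional assay on MCF7 cells (Homo sapiens) for inhibition, read by sulforhodamine B assay (a higher number here means a weaker inhibitor of growth, a lower number a stronger inhibitor of growth), compound 1 `Cc1ccc2[nH]c(-c3ccc(-c4ccc(-c5ccc(N(C)C)cc5)cc4)cc3)nc2c1` gives 3130 nM, and compound 3 `CN(C)c1ccc(-c2ccc(-c3ccc(-c4nc5c(O)cccc5[nH]4)cc3)cc2)cc1` gives 2310 nM, the two being level, with a 1.4-fold lower number from compound 1 to compound 3 (0.13 log units; within the scatter). Compound 2 `CN(C)c1ccc(-c2ccc(-c3ccc(-c4nc5ccccc5[nH]4)cc3)cc2)cc1` gives 41200 nM, which sets it apart, with a 13-fold higher number from compound 1 to compound 2 (1.12 log units; beyond the scatter) and an 18-fold lower number from compound 2 to compound 3 (1.25 log units; beyond the scatter). Compound 4 `Cc1ccc2[nH]c(-c3ccc(-c4ccc(-c5ccccc5)cc4)cc3)nc2c1` has hydrogen in place of dimethylamino on an aromatic carbon. None of these measured steps touches the dimethylamino group, so they fix neither size nor direction for this change. Going by the values given here, they show only that a single change can be large. No step beyond the scatter is therefore expected, though the uncertainty is wide. The estimated step is a 1.6-fold higher number from compound 1 to compound 4 (0.20 log units; within the scatter). Compound 4 is expected at 5000 nM, with an estimated range of 1200 nM to 25000 nM.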

Compound 4, concentration for 50% growth inhibition: 31600 nM
The estimate for compound 4 lay 6.3-fold (0.80 log units) below the measured number; measured number outside the range, above it.
By their numbers in this assay, from the lowest: compounds 3 and 1 (each within the scatter of the next); then compounds 4 and 2 (each within the scatter of the next).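

In this assay, taking away the dimethylamino group gives a 10-fold higher number from compound 1 to compound 4 (1.00 log units; beyond the scatter), so growth inhibition weakens by a step beyond the scatter. Going by these compounds alone, this is the first sign that this position of the core of compound 1 matters, since no earlier step touched it. No evidence here bears on the reason for this loss.

From the compounds shown here alone, it stays open whether a methoxy group, a primary amine or a morpholine would serve in place of dimethylamino at this position. Going by these compounds, it also stays open whether removing dimethylamino costs as much on the core of compound 3.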